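Pyridin-2-yl in place of phenyl: compound 1 to compound 4

A few compounds are considered here, and "the series" means these few. Any claim that something is new, unique, unknown or untested is made for them only; others in the source may bear on it.

Compound 1 `CCCCCCCC/C=C\CCCCCCC(=O)c1ncc(-c2ccccc2)o1`: 320 nM
Compound 2 `CCCCCCCCCCCCCC(=O)C(F)(F)F`: 490 nM
Compound 3 `O=C(O)c1cccc(CCCCCCC(=O)c2ncc(-c3ccccn3)o2)c1`: a limit, > 600 nM

In an assay on isolated protein for inhibition of Fatty-acid amide hydrolase 1 (Homo sapiens) (on this read-out lower numbers stand for stronger inhibition and higher numbers for weaker inhibition), compound 1 gives 320 nM and compound 2 gives 490 nM; the two numbers lie within the scatter of each other, so neither stands apart. For compound 3 only a limit is known, > 600 nM, (the limit of > 600 nM in this assay, at which 1 of the 3 values shown sits). Compound 4 `CCCCCCCC/C=C\CCCCCCC(=O)c1ncc(-c2ccccn2)o1` is not yet measured. It differs from compound 1 in one place: pyridin-2-yl in place of phenyl on an aromatic carbon. Compound 3 carries the same pyridin-2-yl but on a different chain and reaches only a limit, so it does not settle this step. The step from compound 1 to compound 4 is expected to lower the number beyond the scatter: a 4.6-fold lower number from compound 1 to compound 4 (0.66 log units; beyond the scatter). Compound 4 is estimated at 70 nM, from 15 nM to 300 nM.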

Compound 4, inhibition constant: 18 nM
The estimate for compound 4 lay 3.9-fold (0.59 log units) above the measured number; the measured number falls inside the stated range.
By their numbers in this assay, from the lowest: compound 4; then compounds 1 and 2 (each within the scatter of the next). At a limit, above all of these: compound 3.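

In this assay, pyridin-2-yl in place of phenyl gives an 18-fold lower number from compound 1 to compound 4 (1.25 log units; beyond the scatter), so this position, next to the ring oxygen, responds strongly to the change with the chain held constant. The swap keeps the heavy-atom count and adds one ring nitrogen and one hydrogen-bond acceptor. Compound 3 carries the same pyridin-2-yl on a different chain and is known only as a limit, so it gives no second reading of this change: the limit of > 600 nM in this assay, at which 1 of the 4 values shown sits.

Whether the ring nitrogen must sit where it does in pyridin-2-yl stays open, as pyridin-3-yl and pyridin-4-yl are absent from the compounds shown. Also open, on these data alone, is whether an amine on this ring would keep the lower number.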